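Aryl replacement on an aromatic carbon of the shared core

The source may report more compounds than this note shows. Statements on the series, on what has been measured and on what is new or still open speak of the compounds shown alone.

Compound 2 `CC(C)(C)Cc1c(-c2ccccn2)sc(N)c1C(=O)c1ccc(Cl)cc1` stands level with compound 1 `CC(C)Cc1csc(N)c1C(=O)c1ccc(Cl)cc1` and compound 3 `CC(C)(C)Cc1c(-c2ccc(Cl)c(Cl)c2)sc(N)c1C(=O)c1ccc(Cl)cc1` in an assay on CHO cells for displacement of a labelled ligand from adenosine receptor A1 (Homo sapiens), read by scintillation counting, tested at 10 uM; a lower number here means less inhibition, a higher number more inhibition at the concentration tested (going by the name of the read-out): compound 2 gives 1%, compound 1 gives 1% and compound 3 gives 1%. Compound 4 `CC(C)c1ccc(-c2sc(N)c(C(=O)c3ccc(Cl)cc3)c2CC(C)(C)C)cc1` differs from compound 2 by 4-isopropylphenyl in place of pyridin-2-yl on an aromatic carbon. Among the measured compounds shown here, the one measured step that bears on this, another aryl replacement on an aromatic carbon of the core, is no change at the digits printed from compound 2 to compound 3 (within the scatter). Every value in the series sits at the same low level, so in this assay no step beyond the scatter is expected; the step meant by the estimate is a number 1 percentage points higher from compound 2 to compound 4 (within the scatter). Compound 4 is therefore estimated at 2% in this assay, with a range from 0% to 12%.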

Compound 4, a percentage reported as inhibition, at one concentration (the size of the read-out at that concentration, not a potency): 1%
Estimate against measurement, compound 4: 1 percentage points above, within the range that was stated.
By their numbers in this assay, from the lowest: compounds 1, 2, 3 and 4 (each within the scatter of the next).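

In this assay, the place next to the ring sulfur accepts 4-isopropylphenyl, with no ring nitrogen and no hydrogen-bond acceptor, and the reading stays put: no change at the digits printed from compound 2 to compound 4 (within the scatter) and no change at the digits printed from compound 3 to compound 4 (within the scatter). Pyridin-2-yl, 3,4-dichlorophenyl and 4-isopropylphenyl therefore read alike at this position, so the change of aryl group gives no handle on inhibition here. No measurement at hand offers an explanation for this flat reading.

With all readings at this one low level, the aryl groups cannot be ranked. From the compounds shown here alone, whether an aminomethyl group or a carboxylic acid at this place would lift inhibition stays open.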